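The source may hold more compounds than are shown below. What is called first, only, known or untested is meant among the compounds shown, and "the series" means these compounds.

Within the data shown here, in a functional assay on HCT-116 cells (Homo sapiens) for inhibition, read by CCK-8 assay, with a stated time of 72 h, tested at 8 uM (a higher number here means more inhibition of growth at the concentration tested, a lower number less inhibition of growth), compound 1 (`COc1ccc(SCc2ccc(C(=O)Nc3ccccc3N)cc2)cc1`) gives 90.1%, the higher of the two numbers so far. Compound 2 (`CC(C)(C)c1ccc(SCc2ccc(C(=O)Nc3ccccc3N)cc2)cc1`) gives 60.5%. Compound 3 (`COc1ccc(SCc2ccc(C(=O)Nc3ccccc3N)cc2)cc1OC`) keeps the core of compound 1 and differs at one place: methoxy in place of hydrogen on an aromatic carbon. In words, this is methoxy in place of hydrogen on an aromatic carbon. Among the measured compounds shown here, only one measured step bears on it, a number 29.6 percentage points lower from compound 1 to compound 2 (beyond the scatter), with tert-butyl in place of methoxy on an aromatic carbon. That step is modest but removes the methoxy group, whereas compound 3 keeps it and gains a second one, so it is only a loose guide. A fall smaller than that step is expected in this assay, and it may not exceed the scatter. The estimated step is a number 12.1 percentage points lower from compound 1 to compound 3 (beyond the scatter). For compound 3 the estimate is 78%, with an expected range of 55% to 95%.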

Compound 3, percent growth inhibition at one concentration: 91.5%
Beside the measured number, compound 3's estimate is 13.5 percentage points below it, and the stated range covers the measured number.
By their numbers in this assay, from the lowest: compound 2; then compounds 1 and 3 (each within the scatter of the next).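

In this assay, methoxy in place of hydrogen on the aromatic carbon ortho to a methoxy group and meta to a large group gives a number 1.4 percentage points higher from compound 1 to compound 3 (within the scatter), so compound 1 and compound 3 cannot be told apart in this read-out. The earlier step, a number 29.6 percentage points lower from compound 1 to compound 2 (beyond the scatter), showed only that replacing the existing methoxy with tert-butyl matters; this result adds that a second methoxy at this new place is tolerated at the single concentration tested. Nothing available here explains this tolerance.

On these data alone, whether the same carbon also accepts a hydroxyl, an amine, a chlorine atom or a longer chain such as butoxy remains open. Also open, as far as these compounds go, is whether compound 1 and compound 3 would separate across a range of concentrations.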